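This account rests on a few compounds, and the source may have more. Where it says the series, first, only, none or still open, it means among the compounds named here.

Compound 1 `CCCCCCCCCCCCCCCc1cc(=O)c2c(O)c(C)c(OCOC)cc2o1`: > 87000 nM
Compound 2 `CCCCC/C=C\C/C=C\CCCCCCCc1cc(=O)c2c(O)c(C)c(OCOC)cc2o1`: > 87000 nM
Compound 3 `CCCCC/C=C\C/C=C\CCCCCCCc1cc(=O)c2c(O)cc(OCOC)c(C)c2o1`: 16100 nM

In a functional assay on MDA-MB-231 cells (Homo sapiens) for antiproliferative activity, read by MTT assay (a higher number here means a weaker inhibitor, a lower number a stronger inhibitor), compound 1 gives only a limit, > 87000 nM. Compound 2 likewise gives only a limit, > 87000 nM. Within the data shown here, compound 3 is the one compound with a number, 16100 nM. Compound 2 and compound 3 share the same atoms joined differently; the difference between their cores is not broken down here. The change octyl in place of deca-1,4-dien-1-yl on a saturated chain carbon, seven bonds along the chain from an aromatic carbon gives a step that the two limits leave unreadable from compound 2 to compound 1, because of the limit of > 87000 nM in this assay, at which 2 of the 3 values shown sit. Compound 4 `CCCCCCCCCCCCCCCc1cc(=O)c2c(O)cc(OCOC)c(C)c2o1` carries the core of compound 3 with the same kind of change, (octyl in place of deca-1,4-dien-1-yl on a saturated chain carbon, seven bonds along the chain from an aromatic carbon). Its step is expected to be a 2.5-fold higher number from compound 3 to compound 4 (0.40 log units; beyond the scatter), resting only on compound 3 at 16100 nM, since the earlier step is unreadable. Compound 4 is therefore estimated at 40000 nM, between 12000 nM and 90000 nM.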

Compound 4, half-maximal inhibitory concentration: > 87000 nM
Compound 4 was reported as a limit; the forecaster's own chance of this, stated with the estimate: 40%; middle value at least 2.1-fold (0.33 log units) away from the limit.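

In this assay, putting octyl in place of deca-1,4-dien-1-yl on the core of compound 3 gives an at least 5.4-fold higher number from compound 3 to compound 4 (0.73 log units; beyond the scatter). From the compounds shown here alone, compound 4 gives > 87000 nM, which is a limit and not a number, so the change clearly weakens activity on this core, but its full size stays unknown. The same change on the other core, from compound 2 to compound 1, cannot be read, so carrying it from one core to the other remains untested, because both of those compounds also sit at the limit: the limit of > 87000 nM in this assay, at which 3 of the 4 values shown sit.

The change removes both double bonds and alters the chain, so the compounds shown cannot separate these two differences; a decyl group in the same place could help. Also open, going by these compounds, is how a chain carrying an amine would behave in this assay.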